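The compounds below may be only part of what the source reports. "The series", "measured", "known", "first", "only" and "open" are said of these compounds alone.

Compound 1 `O=C(CCCc1ccccc1)N[C@H]1CCOC1=O`: > 100000 nM
Compound 2 `O=C(CCCCCCCCCCc1ccccc1)N[C@H]1CCOC1=O`: 66000 nM
Compound 3 `O=C(CCCCCCCc1ccccc1)CC(=O)N[C@H]1CCOC1=O`: 10000 nM

All three compounds were tested in a functional assay on NCI-H630 cells (Homo sapiens) for cytotoxicity, read by sulforhodamine B assay, with a stated time of 5 days; on this read-out higher numbers stand for weaker inhibition and lower numbers for stronger inhibition. For compound 1, the reading of > 100000 nM is a limit and not a number. Compound 2 stands at 66000 nM, the higher of the two actual numbers, and compound 3 lies lower at 10000 nM, a gap beyond the scatter.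

Compound 4 `O=C(CCCCCCCCCCCc1ccccc1)N[C@H]1CCOC1=O` departs from compound 2 by one change: benzyl in place of phenyl on a saturated chain carbon, ten or more bonds along the chain from a carbonyl carbon. Among the measured compounds shown here, no measured pair shows this change alone. The expected step of a 1.2-fold lower number from compound 2 to compound 4 (0.08 log units; within the scatter) in this assay is none beyond the scatter. Compound 4 is estimated at 55000 nM, with an expected range from 25000 nM to 100000 nM.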

Compound 4, half-maximal inhibitory concentration: > 100000 nM
Compound 4 ended at the assay's limit; the forecaster's own chance of this, stated with the estimate: 15%; at least 1.8-fold (0.25 log units) between middle value and limit.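

In this assay, benzyl in place of phenyl on a saturated chain carbon, ten or more bonds along the chain from a carbonyl carbon, gives a step (an at least 1.5-fold higher number from compound 2 to compound 4 (0.18 log units; that floor lies within the scatter)). Compound 4 reads as a limit and not a number. The step is therefore only a floor, and it does not establish a real loss on lengthening at this position: the limit of > 100000 nM in this assay, at which 2 of the 4 values shown sit.

As far as these compounds go, whether an amine or a carboxylic acid in place of phenyl at this position would give a number under the limit remains open.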